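A few compounds are considered here, and "the series" means these few. Any claim that something is new, unique, unknown or untested is made for them only; others in the source may bear on it.

Three compounds have been measured so far in a functional assay on MV4-11 cells (Homo sapiens) for antiproliferative activity, read by resazurin assay, with a stated time of 72 h; a higher number here means a weaker inhibitor of growth, a lower number a stronger inhibitor of growth:

- Compound 1 `CC(=O)N1CCCN(c2cccc(Nc3nccc(-c4c[nH]c5ncccc45)n3)c2)CC1` gives 20 nM
- Compound 2 `CN1CCN(c2cccc(Nc3nccc(-c4c[nH]c5ncccc45)n3)c2)CC1` gives 5 nM
- Compound 3 `CC(=O)N1CCN(c2ccc(Nc3nccc(-c4nn(C)c5ccccc45)n3)cc2)CC1` gives 181 nM

Compound 1 holds the middle place of the three, with a higher number than compound 2 and a lower one than compound 3. Compound 4 `CC(=O)N1CCCN(c2cccc(Nc3nccc(-c4n[nH]c5ccccc45)n3)c2)CC1` keeps the rest of compound 1 but carries 1H-indazol-3-yl on the aromatic carbon in place of the group found there in compound 1 (a group of 9 heavy atoms (7 carbon, 2 nitrogen; one five-membered aromatic ring with 2 hetero atoms, one six-membered aromatic ring of carbon only) in place of a group of 9 heavy atoms (7 carbon, 2 nitrogen; one five-membered aromatic ring with 1 hetero atom, one six-membered aromatic ring with 1 hetero atom), on an aromatic carbon).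

Among the measured compounds shown here, no measured step changes this group alone. For the measured compounds named here, the one available step, a 4.0-fold lower number from compound 1 to compound 2 (0.60 log units; beyond the scatter), was made at a different place, and so gives only a rough idea of how far a single change can move the number. Compound 3, which also has a carbon-only six-membered ring in the group at this place, gives 181 nM, but it differs from compound 1 in other places too, so it is weak evidence. A modest rise in the number is therefore expected, though no change beyond the scatter remains possible.

The expected change is a 2.0-fold higher number from compound 1 to compound 4 (0.30 log units; within the scatter). Compound 4 is estimated at 40 nM, with an expected range of 12 nM to 140 nM.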

Compound 4, concentration for 50% growth inhibition: 18 nM
Estimate against measurement, compound 4: 2.2-fold (0.35 log units) above, and the stated range covers the measured number.
By their numbers in this assay, from the lowest: compound 2; then compounds 4 and 1 (each within the scatter of the next); then compound 3.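

Compound 4 takes 1H-indazol-3-yl on an aromatic carbon of a six-membered aromatic ring with 2 nitrogen, and this assay shows a 1.1-fold lower number from compound 1 to compound 4 (0.05 log units; within the scatter), so the two compounds cannot be told apart. At this place, then, the group of compound 1 can give way to one with a five-membered aromatic ring with 2 hetero atoms and a six-membered aromatic ring of carbon only, with no difference beyond the scatter. No measurement is at hand that would explain this result.

The compounds shown leave open whether 1H-indazol-3-yl would give the same number alongside 4-methylpiperazin-1-yl, the group behind a 4.0-fold lower number from compound 1 to compound 2 (0.60 log units; beyond the scatter) in the earlier pair. They also leave open how a group such as indol-3-yl or a plain phenyl would read at this place.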